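Trimethoxyphenyl in Place of Methoxyphenyl on the Shared Core

The source may report more compounds than this note shows. Statements on the series, on what has been measured and on what is new or still open speak of the compounds shown alone.

Compound 1 `COc1cc(/C=C/C(=O)c2cccc(-n3cc(-c4ccc(Cl)cc4)[nH]c3=O)c2)cc(OC)c1OC` gives 3690 nM in a functional assay on K562 cells (Homo sapiens) for inhibition (on this read-out higher numbers stand for weaker inhibition of growth and lower numbers for stronger inhibition of growth), while compound 2 `COc1ccc(-c2cn(-c3cccc(C(=O)/C=C/c4cc(OC)c(OC)c(OC)c4)c3)c(=O)[nH]2)cc1` gives 1270 nM in this assay. The step of a 2.9-fold lower number from compound 1 to compound 2 (0.46 log units; beyond the scatter) lies beyond the scatter, so compound 2 stands at the lower of the two numbers. Compound 3 `COc1cc(/C=C/C(=O)c2cccc(-n3cc(-c4cc(OC)c(OC)c(OC)c4)[nH]c3=O)c2)cc(OC)c1OC` differs from compound 2 by 3,4,5-trimethoxyphenyl in place of 4-methoxyphenyl on an aromatic carbon. Among the measured compounds shown here, no measured step covers this exchange; the only known step, a 2.9-fold lower number from compound 1 to compound 2 (0.46 log units; beyond the scatter), concerns a different group at the same position and was modest. Compound 3 is therefore expected to give a step of a 1.3-fold lower number from compound 2 to compound 3 (0.10 log units; within the scatter) that does not clearly exceed the scatter. Compound 3 is estimated at 1000 nM, between 300 nM and 3500 nM.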

Compound 3, concentration for 50% growth inhibition: 590 nM
Beside the measured number, compound 3's estimate is 1.7-fold (0.23 log units) above it; measured number inside the range.
By their numbers in this assay, from the lowest: compound 3; then compound 2; then compound 1.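

In this assay, this aromatic carbon of the shared core tolerates the larger 3,4,5-trimethoxyphenyl and gives a further gain, with a 2.2-fold lower number from compound 2 to compound 3 (0.33 log units; beyond the scatter). Across the three groups at this position, the span widens to a 6.3-fold lower number from compound 1 to compound 3 (0.80 log units; beyond the scatter), which puts 3,4,5-trimethoxyphenyl at the lowest number of the three. Nothing shown here explains these steps. As far as these compounds go, it remains open whether the gain depends on all three methoxy groups, and whether ethoxy groups, an amine or a carboxylic acid on this phenyl ring would lower the number further.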